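This account rests on a few compounds, and the source may have more. Where it says the series, first, only, none or still open, it means among the compounds named here.

In a functional assay on T47D cells (Homo sapiens) for antiproliferative activity, read by MTT assay, with a stated time of 72 h (a lower number here means a stronger inhibitor, a higher number a weaker inhibitor), compound 1 (`COc1cc(-c2nccn2C(C)C)cc(OC)c1OC`) gives > 100000 nM, a limit of the assay and not a number. Compound 2 (`COc1cc(-c2nccn2Cc2ccccc2)cc(OC)c1OC`) gives > 100000 nM, which is also a limit, so it stands with compound 1 at the limit of > 100000 nM in this assay, at which 2 of the 2 values shown sit. Compound 3 (`COc1cccc(-n2ccnc2-c2cc(OC)c(OC)c(OC)c2)c1`) has 3-methoxyphenyl in place of benzyl on an aromatic nitrogen, (3-methoxyphenyl in place of benzyl on an aromatic nitrogen). Among the compounds with values here, the only measured step bearing on this is a step that the two limits leave unreadable from compound 1 to compound 2, and it offers no size to carry over. Only a modest move toward stronger inhibition in this assay is therefore expected, and another limit remains quite possible. The estimated change is an at least 1.6-fold lower number from compound 2 to compound 3 (0.22 log units; that floor lies within the scatter). For compound 3 the expected value is 60000 nM, with an estimated range from 10000 nM to 200000 nM.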

Compound 3, half-maximal inhibitory concentration: 32200 nM
Beside the measured number, compound 3's estimate is 1.9-fold (0.27 log units) above it, and the stated range covers the measured number.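

Within the data shown here, on this aromatic nitrogen, 3-methoxyphenyl in place of benzyl gives the first readable number in this assay, with an at least 3.1-fold lower number from compound 2 to compound 3 (0.49 log units; beyond the scatter). Against isopropyl, the same group gives an at least 3.1-fold lower number from compound 1 to compound 3 (0.49 log units; beyond the scatter). The step between the two earlier groups cannot be read, so they alone showed no order at this position: the limit of > 100000 nM in this assay, at which 2 of the 3 values shown sit.

The compounds shown leave open whether the step belongs to the methoxy group or to the phenyl ring itself. Going by these compounds, how a plain phenyl, or a phenyl carrying an amine or a hydroxyl in place of the methoxy, would behave also remains open.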